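Notes on a single aryl exchange from compound 1

A few compounds are considered here, and "the series" means these few. Any claim that something is new, unique, unknown or untested is made for them only; others in the source may bear on it.

Compound 1 `COc1ccccc1/C=C/C(=O)c1ccc(OCC(=O)N[C@H]2CCOC2=O)cc1` is the reference point of these notes. In a functional assay on MCF7 cells (Homo sapiens) for antiproliferative activity, read by MTT assay, with a stated time of 72 h (a higher number here means a weaker inhibitor, a lower number a stronger inhibitor), compound 1 gives > 64000 nM, which is a limit of the assay and not a number. Compound 2 `O=C(CNc1ccccc1F)N[C@H]1CCOC1=O` and compound 3 `CCOc1ccccc1OCCSC(=S)N[C@H]1CCOC1=O` stand alongside it. In this assay compound 2 gives > 64000 nM, again only a limit. In this assay compound 3 gives > 64000 nM, also a limit. Among the compounds with values here, all that is known of where compound 1 stands is therefore (the limit of > 64000 nM in this assay, at which 3 of the 3 values shown sit); no measured pair differs in a single place, so no step size has yet been seen.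

Compound 4 `O=C(COc1ccc(C(=O)/C=C/c2cccc(F)c2)cc1)N[C@H]1CCOC1=O` is the compound still to be measured. It differs from compound 1 in one place: 3-fluorophenyl in place of 2-methoxyphenyl on a double-bonded chain carbon bound to a double-bonded chain carbon. With every known value sitting at the limit, there is no direction to carry forward. In this assay the expected step is a step that the limit leaves unreadable from compound 1 to compound 4, none beyond the scatter. Compound 4 is estimated to give about 70000 nM in this assay, within a range from 20000 nM to 200000 nM, and most probably it is reported once more only as a limit.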

Compound 4, half-maximal inhibitory concentration: > 64000 nM
Compound 4 ended at the assay's limit (the forecaster's own chance of this, stated with the estimate: 75%); the middle value does not contradict the limit.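

No step can be read from compound 1 to compound 4, since in this assay both are reported only as a limit of the assay, so 3-fluorophenyl in place of 2-methoxyphenyl has no readable effect: the limit of > 64000 nM in this assay, at which 4 of the 4 values shown sit.

The compounds shown leave open whether any member of this series gives a measured value rather than a limit in this assay.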